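A few compounds are considered here, and "the series" means these few. Any claim that something is new, unique, unknown or untested is made for them only; others in the source may bear on it.

Measured so far in a functional assay on HepG2 cells (Homo sapiens) for cytotoxicity, read by sulforhodamine B assay, with a stated time of 48 h; on this read-out lower numbers stand for stronger inhibition and higher numbers for weaker inhibition:
- compound 1, `Cc1ccc(S(=O)(=O)Nc2ccc(-c3cc(-c4ccc([N+](=O)[O-])cc4)[nH]n3)cc2)cc1`: 44800 nM
- compound 2, `C/C(=N/NC(=O)C(C#N)C(=S)S)c1ccc(NS(=O)(=O)c2ccc(C)cc2)cc1`: 11000 nM
- compound 3, `COc1ccc(-c2c(C#N)c(N)n(/N=C(/C)c3ccc(NS(=O)(=O)c4ccc(C)cc4)cc3)c(=O)c2C#N)cc1`: 31800 nM

Compound 1 gives the highest number of the three in this assay. Its nearest neighbour is compound 3, whose value sits within the scatter of that of compound 1, so no order can be read between these two. Going by the values given here, compound 2 stands furthest away, with a number that is lower by more than the scatter; of the three only this pair shows a gap that is clearly resolved.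

Compound 4, `Cc1ccc(S(=O)(=O)Nc2ccc(-c3cc(-c4ccc([N+](=O)[O-])cc4)n(-c4ccccc4)n3)cc2)cc1`, has not yet been measured in this assay. It departs from compound 1 in one place: phenyl in place of hydrogen on an aromatic nitrogen. The change is confined to the five-membered aromatic ring with two nitrogens; the sulfonamide and the 4-nitrophenyl group are unchanged.

Among the compounds with values here, no measured pair in this set isolates a comparable change, so there is no step to lean on. The expectation is that the step from compound 1 to compound 4 in this assay will be small, at most a modest move toward a lower number and quite possibly none beyond the scatter, estimated as a 1.5-fold lower number from compound 1 to compound 4 (0.17 log units; within the scatter). Compound 4 is therefore expected to give about 30000 nM in this assay, with a range from 12000 nM to 80000 nM.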

Compound 4, half-maximal inhibitory concentration: "not active" (no number reported)
For compound 4 the study gives words and no number; there is nothing to compare the estimate with.
By their numbers in this assay, from the lowest: compound 2; then compounds 3 and 1 (each within the scatter of the next).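

In this assay, going by these compounds alone, compound 4 is reported only in words, as "not active", so no step from compound 1 to compound 4 can be read. The compounds shown leave open how far phenyl in place of hydrogen on an aromatic nitrogen moves the number in this series. No evidence bearing on this result is available.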